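From Benzofuran to a Plain Hexyl Chain

The source may hold more compounds than are shown below. What is called first, only, known or untested is meant among the compounds shown, and "the series" means these compounds.

Of the compounds shown here, three have been tested in an in vitro functional assay on RBL cells for antagonist activity at C-C chemokine receptor type 8 (Homo sapiens), read by FLIPR and calcium flux; a lower number here means a stronger inhibitor, a higher number a weaker inhibitor. Compound 1, `COc1ccc2nccc(C3CN(C4CCN(Cc5cc6ccccc6[nH]5)C4)C(=O)O3)c2c1`, registers only as a limit in this assay, recorded as < 50200 nM. Compound 2, `COc1ccc2nccc(C3CN(C4CCN(Cc5cc6ccccc6[nH]5)CC4)C(=O)O3)c2n1`, gives 31.6 nM in this assay. Compound 3, `COc1ccc2nccc(C3CN(C4CCN(Cc5cc6ccccc6o5)CC4)C(=O)O3)c2c1`, gives 1260 nM in this assay and thus holds the higher of the two measured numbers, standing well apart from compound 2, a gap beyond the usual scatter.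

The next compound, compound 4, `CCCCCCN1CCC(N2CC(c3ccnc4ccc(OC)cc34)OC2=O)CC1`, keeps the shared core of compound 3 and alters only the group on the ring nitrogen: pentyl in place of 1-benzofuran-2-yl on a saturated chain carbon bound to an amine nitrogen in a ring. Going by the values given here, a bicyclic aromatic substituent is thus exchanged for a plain saturated chain, and no measured pair with such a change exists to guide the estimate.

Since compound 3 already gives 1260 nM, the account expects the step from compound 3 to compound 4 to move the number upward, toward weaker inhibition, by a margin beyond the scatter, which is expressed as a 4.0-fold higher number from compound 3 to compound 4 (0.60 log units; beyond the scatter). For compound 4 itself the expected value in this assay is 5000 nM, with a range from 1000 nM to 25000 nM, and some chance that only a limit is reported.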

Compound 4, half-maximal inhibitory concentration: 501 nM
Compound 4: middle estimate off by 10-fold (1.00 log units), on the high side, outside the stated range (below it).
By their numbers in this assay, from the lowest: compound 2; then compound 4; then compound 3.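

On the ring nitrogen, the change from (1-benzofuran-2-yl)methyl to hexyl gives a 2.5-fold lower number from compound 3 to compound 4 (0.40 log units; beyond the scatter) in this assay, so at this place a plain saturated chain with no ring and no hydrogen-bond acceptor outperforms the benzofuran-bearing group. Going by these compounds alone, all the earlier compounds carry a bicyclic aromatic group at this place, so they could not show that measurable inhibition persists without any ring there, or that removing the benzofuran can lower the number rather than raise it. The data at hand offer nothing that accounts for the size or direction of this step.

Going by these compounds, only one saturated chain appears at this place, so it remains open how the number would respond to a shorter chain, a longer chain or a branched one, and the hexyl result alone defines no preferred length. Also open, on these data alone, is whether an amine or a carboxylic acid at the far end of the hexyl chain, or a phenyl ring carried on it, would keep, lower or raise the number seen with the plain chain.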